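The source may hold more compounds than are shown below. What is called first, only, known or untested is meant among the compounds shown, and "the series" means these compounds.

In a functional assay on A549 cells (Homo sapiens) for antiproliferative activity, read by MTT assay, with a stated time of 48 h (a higher number here means a weaker inhibitor, a lower number a stronger inhibitor), compound 1 `N#CC1=C(N)Oc2c(c3nc4ccccc4nc3c3ccccc23)C12C(=O)N(Cc1cnnn1-c1cccc(Cl)c1)c1ccccc12` gives 32600 nM. Compound 2 `N#CC1=C(N)Oc2c(c3nc4ccccc4nc3c3ccccc23)C12C(=O)N(Cc1cnnn1-c1ccc(N)cc1)c1ccccc12` gives only the limit > 50000 nM in this assay. Compound 3 `N#CC1=C(N)Oc2c(N)cc3nc4ccccc4nc3c2C12C(=O)N(Cc1cnnn1-c1ccc(F)cc1)c1ccccc12` likewise gives only the limit > 50000 nM in this assay.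

Compound 3 thus has no measured number, only a limit, one that two of the three values share (the limit of > 50000 nM in this assay, at which 2 of the 3 values shown sit). Compound 4 `N#CC1=C(N)Oc2c(N)cc3nc4ccccc4nc3c2C12C(=O)N(Cc1cnnn1-c1ccccc1Br)c1ccccc12` differs from compound 3 in one place: 2-bromophenyl in place of 4-fluorophenyl on an aromatic nitrogen. Among the measured compounds shown here, the only measured step at the same aromatic nitrogen is an at least 1.5-fold higher number from compound 1 to compound 2 (0.18 log units; that floor lies within the scatter), made on a different core, and it does not rise beyond the scatter. That step offers little guidance, and compound 3 itself supplies only a limit. Compound 4 is therefore expected to remain weak, an estimated at least 1.2-fold lower number from compound 3 to compound 4 (0.09 log units; that floor lies within the scatter), at about 40000 nM with a range from 15000 nM to 100000 nM.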

Compound 4, half-maximal inhibitory concentration: 27400 nM
Estimate against measurement, compound 4: 1.5-fold (0.16 log units) above, and the stated range covers the measured number.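

In this assay, 2-bromophenyl on this aromatic nitrogen gives a measured number on the core of compound 3, where 4-fluorophenyl gives none, and the step is an at least 1.8-fold lower number from compound 3 to compound 4 (0.26 log units; that floor lies within the scatter). The true step may be larger, but this floor alone does not establish a real gain. Compound 3 still stands as a limit, not a number: the limit of > 50000 nM in this assay, at which 2 of the 4 values shown sit.

Bromine and its place on the phenyl ring change together here, so their contributions stay unseparated. A 4-bromophenyl or an unsubstituted phenyl on this core would help to separate them.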